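Trimming one methoxy group from compound 1

A few compounds are considered here, and "the series" means these few. Any claim that something is new, unique, unknown or untested is made for them only; others in the source may bear on it.

Measured so far in a functional assay on ACHN cells (Homo sapiens) for inhibition, read by sulforhodamine B assay, with a stated time of 48 h; on this read-out higher numbers stand for lower toxicity in this test and lower numbers for higher toxicity in this test:
Compound 1, `COc1cc(-c2cc(/C=C/C(=O)c3ccc(N)cc3)[nH]n2)cc(OC)c1OC`, gives 8400 nM.
Compound 2, `COc1ccc(-c2cc(/C=C/C(=O)c3ccc(OC)c(OC)c3)[nH]n2)cc1`, gives 8710 nM.
Compound 3, `COc1cc(-c2cc(/C=C/C(=O)c3ccc(Cl)c(Cl)c3)[nH]n2)cc(OC)c1OC`, reaches only a limit, > 100000 nM.

Compound 1 holds the lowest of the two numbers shown, and compound 2 lies within the usual scatter of it, so the two cannot be told apart. Compound 3 stands at the limit of the assay, (the limit of > 100000 nM in this assay, at which 1 of the 3 values shown sits), and its value is not a number. Within the data shown here, the only step between compounds that differ in one place is an at least 11-fold higher number from compound 1 to compound 3 (1.07 log units; beyond the scatter), a change on the carbonyl carbon that has nothing to do with the ring on the other side of the core.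

Compound 4, `COc1ccc(-c2cc(/C=C/C(=O)c3ccc(N)cc3)[nH]n2)cc1OC`, differs from compound 1 by hydrogen in place of methoxy on an aromatic carbon. Among the measured compounds shown here, no measured step touches this place. Compound 2 differs from compound 1 at this ring and also on the carbonyl side, and its value sits within the scatter of compound 1, which gives no sign of a large effect of the methoxy pattern, though it is not a clean comparison. Compound 4 is therefore expected to show a 1.1-fold higher number from compound 1 to compound 4 (0.03 log units; within the scatter), with no step beyond the scatter. The estimate for compound 4 is 9000 nM, expected to fall between 4000 nM and 22000 nM.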

Compound 4, concentration lethal to 50% of the cells: 6480 nM
Estimate against measurement, compound 4: 1.4-fold (0.14 log units) above; measured number inside the range.
By their numbers in this assay, from the lowest: compounds 4, 1 and 2 (each within the scatter of the next). At a limit, above all of these: compound 3.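

In this assay, among these compounds, the change of hydrogen in place of methoxy on an aromatic carbon now stands alone for the first time, and it gives a 1.3-fold lower number from compound 1 to compound 4 (0.11 log units; within the scatter). The earlier compounds shown here offered no step at this place, since compound 2 changes this ring and the carbonyl side together; here the 4-aminophenyl group stays fixed, and the removal of the methoxy group, from a carbon ortho to a methoxy group and meta to a large group, leaves a result that cannot be told apart from compound 1. Nothing given here bears on the cause of this result.

What the compounds shown leave open is whether this place tolerates anything other than hydrogen and methoxy, such as a hydroxyl group, a fluorine atom, an amine or a longer chain like ethoxy, since one step on one background marks out only a small part of what could sit there. Also open, going by these compounds, is whether the same step holds with the 3,4-dichlorophenyl group on the carbonyl carbon, as in compound 3, whose > 100000 nM is a limit and not a number.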